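This account rests on a few compounds, and the source may have more. Where it says the series, first, only, none or still open, it means among the compounds named here.

Of the compounds shown here, three built on a shared core have been tested in a functional assay on HCT-116 cells (Homo sapiens) for antiproliferative activity, read by MTT assay, with a stated time of 72 h; on this read-out higher numbers stand for weaker inhibition and lower numbers for stronger inhibition. Compound 1, `O=C(CCc1cccc2c1B(O)OC2)Nc1ccc(Cl)cc1`, gives 12000 nM. Compound 2, `COc1ccc(NC(=O)CCc2cccc3c2B(O)OC3)cc1`, gives 1700 nM. Compound 3, `O=C(CCc1cccc2c1B(O)OC2)Nc1cccc(-c2ccc(Cl)cc2)c1`, gives 380 nM, the lowest of the three numbers, and its steps to both other compounds lie beyond the usual scatter.

Compound 1 and compound 2 differ in one place, (methoxy in place of chloro on an aromatic carbon), and this change brought a 7.1-fold lower number from compound 1 to compound 2 (0.85 log units; beyond the scatter). The difference between the core of compound 1 and the core of compound 3 is not broken down here.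

The unmeasured compound 4, `COc1ccc(-c2cccc(NC(=O)CCc3cccc4c3B(O)OC4)c2)cc1`, is related to compound 3 by methoxy in place of chloro on an aromatic carbon, the same change that turned compound 1 into compound 2; cut one bond further out it reads 4-chlorophenyl to 4-methoxyphenyl. Among these compounds the change occurs twice in all. Among the measured compounds shown here, because the step of a 7.1-fold lower number from compound 1 to compound 2 (0.85 log units; beyond the scatter) was a clear drop in number, a drop is expected for compound 4 as well, but the one earlier example is a thin basis, and the group now sits on a ring that in compound 3 is joined to another ring rather than to the amide, so a smaller step is expected, a 1.9-fold lower number from compound 3 to compound 4 (0.28 log units; within the scatter). The expected value for compound 4 in this assay is 200 nM, with a likely range from 80 nM to 600 nM.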

Compound 4, half-maximal inhibitory concentration: 160 nM
The estimate for compound 4 lay 1.3-fold (0.10 log units) above the measured number, within the range that was stated.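

In this assay the swap of chloro for methoxy gave a 2.4-fold lower number from compound 3 to compound 4 (0.38 log units; beyond the scatter) and thus lowered the number again, so the direction of the change held on both cores. The size of the step did not carry over, since the two steps differ by more than repeated measurements would be expected to explain: the same change on two cores in this assay, a 7.1-fold lower number (0.85 log units; beyond the scatter) from compound 1 to compound 2 and a 2.4-fold lower number (0.38 log units; beyond the scatter) from compound 3 to compound 4, 3.0-fold (0.47 log units) apart, beyond the scatter of two such steps. Among the compounds shown here, these two pairs show that a direction seen on one core was a useful guide to the other, but that the size of a step on one core could not simply be copied to the next; with only two examples, they do not show why the steps differ or whether the direction would hold on any further core.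

From the compounds shown here alone, it remains open whether other groups in the same place on the ring, such as a hydroxyl, an amine or a carboxylic acid, would give lower or higher numbers than methoxy does. Also open, going by these compounds, is whether a longer chain in place of the one that carries the amide would change the size of the step from chloro to methoxy, and whether the same direction would appear in other cell lines.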